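Moving the carboxylic acid and halogen on the terminal ring

The compounds below may be only part of what the source reports. "The series", "measured", "known", "first", "only" and "open" are said of these compounds alone.

Measured compounds in an assay for positive allosteric modulation of metabotropic glutamate receptor 2 (Rattus norvegicus); a lower number here means that less compound is needed, a higher number that more compound is needed for the effect:
compound 1 `Cc1c(OCCCCOc2ccc(Cl)c(C(=O)O)c2)ccc(C(=O)CC(C)(C)C)c1O` gives 87 nM
compound 2 `COc1ccc(OCCCCOc2ccc(C(=O)CC(C)(C)C)c(O)c2C)cc1C(=O)O` gives 13 nM
compound 3 `COc1cc(OCCCCOc2ccc(C(=O)CC(C)(C)C)c(O)c2C)cc(C(=O)O)c1` gives 102 nM

Compound 1 stands second highest of the three numbers in this assay. Its nearest neighbour is compound 3, whose value lies within the scatter of that of compound 1. The furthest is compound 2, reached by the step of a 6.7-fold lower number from compound 1 to compound 2 (0.83 log units; beyond the scatter), a methoxy in place of chloro on an aromatic carbon.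

Compound 4 `Cc1c(OCCCCOc2ccc(C(=O)O)c(F)c2)ccc(C(=O)CC(C)(C)C)c1O` is not yet measured. It differs from compound 1 in this way: 4-carboxy-3-fluorophenyl in place of 3-carboxy-4-chlorophenyl on an oxygen on a saturated carbon. Both the carboxylic acid and the halogen thus change their positions on the terminal ring, and fluorine replaces chlorine.

Among the compounds with values here, no measured step covers this change. Within the data shown here, the only step seen, from compound 1 to compound 2, alters the halogen alone and leaves the carboxylic acid where it is; compound 3 carries its acid and methoxy in yet another arrangement, and its value is within the scatter of compound 1. The rearrangement in compound 4 is therefore uncharted, and a step of any size in either direction is possible, with no firm expectation beyond the scatter.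

Compound 4 is estimated at 150 nM, with a range from 40 nM to 600 nM, which corresponds to an expected step of a 1.7-fold higher number from compound 1 to compound 4 (0.24 log units; within the scatter).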

Compound 4, half-maximal effective concentration: 80 nM
Estimate against measurement, compound 4: 1.9-fold (0.27 log units) above; low and high end bracket the measured number.
By their numbers in this assay, from the lowest: compound 2; then compounds 4, 1 and 3 (each within the scatter of the next).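

In this assay, the exchange of 3-carboxy-4-chlorophenyl for 4-carboxy-3-fluorophenyl on an oxygen on a saturated carbon gives a 1.1-fold lower number from compound 1 to compound 4 (0.04 log units; within the scatter), so this change, with the carboxylic acid and the halogen both moved and fluorine in place of chlorine, leaves the number within the scatter. The earlier compounds had shown this terminal ring only as a place where one exchange, of chloro for methoxy, carries a step beyond the scatter, a 6.7-fold lower number from compound 1 to compound 2 (0.83 log units; beyond the scatter), and the present result adds a much larger rearrangement of the ring that carries no such step. The two parts of the change come together in a single step, so the values cannot tell whether each part alone is without effect or whether the two offset each other, and nothing at hand bears on the closeness of the two values.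

Open, on these data alone, is whether a methoxy in place of the fluoro of compound 4 would reach a number like that of compound 2. Also open, as far as these compounds go, is whether the carboxylic acid at this new position could give way to a tetrazole or an amide.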